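Guanidine tail in place of the amide tail: compound 4

The source may hold more compounds than are shown below. What is called first, only, known or untested is meant among the compounds shown, and "the series" means these compounds.

Compound 1, `Cc1cc(C)c2cccc(OCc3c(Cl)ccc(S(=O)(=O)NC4(C(=O)N5CCN(C(=O)[C@@H](N)CCCCN)CC5)CCCC4)c3Cl)c2n1`: in an assay on isolated protein for binding affinity to B1 bradykinin receptor (Homo sapiens) (a higher number here means a weaker inhibitor, a lower number a stronger inhibitor), compound 1 gives < 10000 nM, which is a limit of the assay rather than a measured number.
Compound 2, `Cc1cc(C)c2cccc(OCc3c(Cl)ccc(S(=O)(=O)NC4(C(=O)N5CCN(C(=O)[C@@H](N)CCCC[N+](C)(C)C)CC5)CCCC4)c3Cl)c2n1`: in this assay compound 2 gives < 10000 nM, again only a limit.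
Compound 3, `Cc1cc(C)c2cccc(OCc3c(Cl)ccc(S(=O)(=O)NC4(C(=O)N5CCN(C(=O)C[C@H](CCCN)[N+](C)(C)C)CC5)CCCC4)c3Cl)c2n1`: in this assay compound 3 gives < 10000 nM, also a limit.

Compound 3 therefore stands exactly where its two relatives stand, at the limit of the assay, since all three values sit there (the limit of < 10000 nM in this assay, at which 3 of the 3 values shown sit). For this reason the steps between them, a step that the two limits leave unreadable from compound 1 to compound 2, a step that the two limits leave unreadable from compound 1 to compound 3 and a step that the two limits leave unreadable from compound 2 to compound 3, cannot be read for size or direction.

Compound 4, `Cc1cc(C)c2cccc(OCc3c(Cl)ccc(S(=O)(=O)NC4(C(=O)N5CCN(C(=N)NCCC[N+](C)(C)C)CC5)CCCC4)c3Cl)c2n1`, differs from compound 3 by a group of 10 heavy atoms (7 carbon, 3 nitrogen; no ring) in place of a group of 12 heavy atoms (9 carbon, 2 nitrogen, 1 oxygen; no ring), on an amine nitrogen in a ring. Among the measured compounds shown here, none of the measured steps carries a readable size, so nothing among them tells how much this change should move the result in this assay, in either direction. What the three values do show is that compound 3 and both other compounds reach the limit, and a compound so close to them is expected to behave alike. The expected step is a step that the limit leaves unreadable from compound 3 to compound 4. Compound 4 is estimated at 800 nM, within a range from 60 nM to 6000 nM, and it may well again be reported only as a limit.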

Compound 4, inhibition constant: < 10000 nM
Compound 4 was reported as a limit; the forecaster's own chance of this, stated with the estimate: 65%; the middle value lies beyond the limit too.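

In this assay compound 4 gives < 10000 nM, which is a limit of the assay and not a number. Its steps from compound 1, compound 2 and compound 3 cannot be read for size or direction, since all four compounds share one limit: the limit of < 10000 nM in this assay, at which 4 of the 4 values shown sit.

The compounds shown leave open how strongly each one binds, and whether changing the group on the ring amine nitrogen alters binding at all.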